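Swapping the Amide Methyl for a Difluorophenyl Ring

This account rests on a few compounds, and the source may have more. Where it says the series, first, only, none or still open, it means among the compounds named here.

Of the compounds shown here, three have so far been tested in a functional assay for antagonist activity at C-X-C chemokine receptor type 3 (Homo sapiens); a lower number here means a stronger inhibitor, a higher number a weaker inhibitor. Compound 1 `CNC(=O)c1cnc(N2CCN(C3CCN(Cc4ccc(Cl)cc4)CC3)[C@@H](C)C2)c(Cl)c1` is the strongest inhibitor of the three, giving 32 nM. Compound 2 `CNC(=O)c1cnc(N2CCN(C3CCN(Cc4ccccn4)CC3)[C@@H](C)C2)c(Cl)c1` gives 7990 nM, and compound 3 `CNC(=O)c1cnc(N2CCN(C3CCN(C(=O)c4ccc(Cl)cc4)CC3)[C@@H](C)C2)c(Cl)c1` gives 210 nM. The steps between them are all changes to the group carried on an amine nitrogen in a ring: a 250-fold higher number from compound 1 to compound 2 (2.40 log units; beyond the scatter), a 6.6-fold higher number from compound 1 to compound 3 (0.82 log units; beyond the scatter) and a 38-fold lower number from compound 2 to compound 3 (1.58 log units; beyond the scatter). Each of these steps is beyond the usual scatter, so this part of the molecule clearly matters for potency.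

Compound 4 `C[C@H]1CN(c2ncc(C(=O)Nc3ccc(F)c(F)c3)cc2Cl)CCN1C1CCN(Cc2ccc(Cl)cc2)CC1` alters compound 1 at a different spot. The change is 3,4-difluorophenyl in place of methyl on an amide-type nitrogen, that is, methylcarbamoyl becomes (3,4-difluorophenyl)carbamoyl while the rest of the shared core is unchanged. Going by the values given here, none of the measured steps touches the amide-type nitrogen, so none of them bears directly on this change, and no measured pair gives a guide to its direction or size. The expectation therefore rests on compound 1 alone and carries wide uncertainty.

Compound 4 is estimated to give 45 nM in this assay, with a range from 8 nM to 300 nM. That estimate corresponds to an expected step of a 1.4-fold higher number from compound 1 to compound 4 (0.15 log units; within the scatter), which is no clear change beyond the scatter.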

Compound 4, half-maximal inhibitory concentration: 22 nM
Compound 4: the middle estimate sits 2.0-fold (0.31 log units) above what was measured; low and high end bracket the measured number.
By their numbers in this assay, from the lowest: compounds 4 and 1 (each within the scatter of the next); then compound 3; then compound 2.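

Putting 3,4-difluorophenyl in place of methyl on the amide-type nitrogen gives a 1.5-fold lower number from compound 1 to compound 4 (0.16 log units; within the scatter) in this assay, so compounds 1 and 4 cannot be told apart in this read-out. Going by these compounds alone, this is the first look at this position, and it shows that a group of 8 heavy atoms with a six-membered aromatic ring can replace a single carbon here without a change beyond the scatter, at least for this one group. The ring amine nitrogen behaves quite differently, since one exchange there gives a 250-fold higher number from compound 1 to compound 2 (2.40 log units; beyond the scatter), but nothing shown explains why the amide-type nitrogen accepts so much larger a group.

As far as these compounds go, whether the two fluorine atoms matter remains open, as does how a plain phenyl, a benzyl or a cyclohexyl on the same nitrogen would read. It is also unknown whether the 3,4-difluorophenyl amide would keep its potency with another group on the ring amine nitrogen, such as the (pyridin-2-yl)methyl of compound 2 or the (4-chlorophenyl)carbonyl of compound 3.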